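A few compounds are considered here, and "the series" means these few. Any claim that something is new, unique, unknown or untested is made for them only; others in the source may bear on it.

Compound 1 `CC(C)c1ccc(-c2cc(=O)c3cc(C(=O)O)ccc3o2)cc1` carries an isopropyl group, and in a functional assay on the whole organism (stomach) for inhibition, with Rattus norvegicus as the target, at a dose of 80 mg/kg (on this read-out lower numbers stand for less inhibition and higher numbers for more inhibition at the one dose given (going by the name of the read-out)), compound 1 gives 19%. That places it second highest of three: compound 3 `O=C(O)c1ccc2oc(-c3ccc(F)cc3)cc(=O)c2c1` gives 21% in this assay, a difference of a number 2 percentage points higher from compound 1 to compound 3 (within the scatter), while compound 2 `CCCCCCc1ccc(-c2cc(=O)c3cc(C(=O)O)ccc3o2)cc1` gives 2%, a step of a number 17 percentage points lower from compound 1 to compound 2 (beyond the scatter). Compound 4 `CC(C)c1ccc(-c2oc3ccc(C(=O)O)cc3c(=O)c2O)cc1` differs from compound 1 by hydroxy in place of hydrogen on an aromatic carbon on the shared core. For the measured compounds named here, none of the measured steps touches this place; a number 17 percentage points lower from compound 1 to compound 2 (beyond the scatter), a number 2 percentage points higher from compound 1 to compound 3 (within the scatter) and a number 19 percentage points higher from compound 2 to compound 3 (beyond the scatter) all exchange the group on an aromatic carbon elsewhere, so they give no guide to a hydroxy entering the core. The expectation is therefore a step of no change at the digits printed from compound 1 to compound 4 (within the scatter), within the scatter. Compound 4 is estimated at 19%, with a range from 4% to 40%.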

Compound 4, a percentage reported as inhibition, in the whole organism at one dose (the size of the read-out at that dose, not a potency): 24%
For compound 4 the middle estimate is 5 percentage points below the measured one; the measured number falls inside the stated range.
By their numbers in this assay, from the lowest: compound 2; then compounds 1, 3 and 4 (each within the scatter of the next).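

In this assay, hydroxy in place of hydrogen on the shared core gives a number 5 percentage points higher from compound 1 to compound 4 (within the scatter) and so stays within the scatter. This is the first change shown on the core itself, and this aromatic carbon, two atoms from the ring oxygen, takes a hydroxy without a change that can be told from repeat measurements. No measurement at hand bears on why. Going by these compounds, whether a methoxy or an amine at this carbon would behave the same stays open, as does whether hydroxy would give a similar result alongside the hexyl of compound 2 or the fluoro of compound 3.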